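Benzoxazole series: amide to pyridyl at the ring carbon

The source may hold more compounds than are shown below. What is called first, only, known or untested is meant among the compounds shown, and "the series" means these compounds.

Measured so far:
compound 1 `C[C@H](c1ccc(-c2ccccc2-c2nc(=O)o[nH]2)cc1)N(CC1CC1)c1nc2c(C(=O)O)cccc2o1` — 11 nM
compound 2 `CCCCN(c1nc2c(C(=O)NC)cccc2o1)[C@H](C)c1ccc(-c2ccccc2-c2nnn[nH]2)cc1` — 110 nM

In a functional assay on CAL1 cells for inhibition of chemerin-like receptor 1 (Homo sapiens), with a stated time of 45 min (a higher number here means a weaker inhibitor, a lower number a stronger inhibitor), compound 2 gives 110 nM, the higher of the two numbers; its nearest neighbour is compound 1, whose value in this assay is 11 nM, a gap beyond the scatter. Compound 3 `CCCCN(c1nc2c(-c3ccccn3)cccc2o1)[C@H](C)c1ccc(-c2ccccc2-c2nnn[nH]2)cc1` is not yet measured. The change from compound 2 to compound 3 is pyridin-2-yl in place of methylcarbamoyl on an aromatic carbon. Within the data shown here, no measured pair isolates this change, so the expectation rests on compound 2 alone. The step of a 1.8-fold higher number from compound 2 to compound 3 (0.26 log units; within the scatter) is expected to be small and towards a weaker inhibitor, possibly none beyond the scatter. Compound 3 is estimated at 200 nM, within 40 nM to 1000 nM.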

Compound 3, half-maximal inhibitory concentration: 110 nM
The estimate for compound 3 lay 1.8-fold (0.26 log units) above the measured number, and the stated range covers the measured number.
By their numbers in this assay, from the lowest: compound 1; then compounds 2 and 3 (each within the scatter of the next).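

In this assay, pyridin-2-yl in place of methylcarbamoyl on this aromatic carbon gives no change at the digits printed from compound 2 to compound 3 (within the scatter). In this one pair, the position accepts a six-membered aromatic ring without the hydrogen-bond donor of methylcarbamoyl, with no change beyond the scatter. No supporting data bear on why the two groups read alike.

On these data alone, the effect of a carboxylic acid on this carbon remains open, as compound 1 differs from compound 2 in more than one place. Also open, as far as these compounds go, is whether pyridin-3-yl or an unsubstituted phenyl would read like pyridin-2-yl.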